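A few compounds are considered here, and "the series" means these few. Any claim that something is new, unique, unknown or untested is made for them only; others in the source may bear on it.

Working notes on the series, read in a functional assay on WM 266-4 cells (Homo sapiens) for antiproliferative activity, read by MTT assay, with a stated time of 48 h; a higher number here means a weaker inhibitor, a lower number a stronger inhibitor. Compound 1 `O=C(Nc1cc(-c2ccccc2)[nH]n1)c1cccnc1F` gives 3770 nM, compound 2 `O=C(Nc1cc(-c2ccccc2)[nH]n1)c1cccnc1Cl` gives 6220 nM and compound 3 `O=C(Nc1cc(-c2ccccc2)[nH]n1)c1cncc(Br)c1` gives 6880 nM. On these numbers compound 3 is not separated from compound 1 or compound 2.

Compound 4 `O=C(Nc1cc(-c2ccccc2)[nH]n1)c1ccc(Br)nc1` carries 6-bromopyridin-3-yl in place of 5-bromopyridin-3-yl on a carbonyl carbon. Within the data shown here, no measured pair holds this exact change. The nearest evidence is the exchange of the same group, seen in a 1.1-fold higher number from compound 2 to compound 3 (0.04 log units; within the scatter) and in a 1.8-fold higher number from compound 1 to compound 3 (0.26 log units; within the scatter). The swap of chloro for fluoro, a 1.6-fold higher number from compound 1 to compound 2 (0.22 log units; within the scatter), is equally small. All three compounds therefore sit together, and none goes against this, though three compounds are a narrow base.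

On that evidence, no step beyond the scatter is expected in this assay. The estimated step is a 1.1-fold lower number from compound 3 to compound 4 (0.06 log units; within the scatter). Compound 4 is expected at 6000 nM, with an estimated range of 3000 nM to 12000 nM.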

Compound 4, half-maximal inhibitory concentration: 6730 nM
The estimate for compound 4 lay 1.1-fold (0.05 log units) below the measured number, within the range that was stated.
By their numbers in this assay, from the lowest: compounds 1, 2, 4 and 3 (each within the scatter of the next).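

Exchanging 5-bromopyridin-3-yl for 6-bromopyridin-3-yl on a carbonyl carbon keeps the same atoms, joined differently, and gives a 1.0-fold lower number from compound 3 to compound 4 (0.01 log units; within the scatter) in this assay, so this exchange does not separate the two compounds. Against the two halogenated groups of the earlier compounds, 6-bromopyridin-3-yl gives a 1.1-fold higher number from compound 2 to compound 4 (0.03 log units; within the scatter) and a 1.8-fold higher number from compound 1 to compound 4 (0.25 log units; within the scatter) in this assay, which leaves all four compounds together, with no step among them beyond the scatter. No measurement shown bears on this result, and no cause can be assigned to it.

On these data alone, whether an amine or a carboxylic acid in place of the bromine would give a step beyond the scatter remains open. So does whether any change on the rest of the shared core would do so.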